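The compounds below may be only part of what the source reports. "The series", "measured", "known", "first", "only" and "open" are said of these compounds alone.

Working notes on the series.

Compound 1, `NC(=O)c1c(NC(=O)c2ccccc2Cl)sc2c1CCN(Cc1ccccc1)C2`, is the reference point. In a functional assay on MKN-74 cells (Homo sapiens) for antiproliferative activity, with a stated time of 24 h (on this read-out lower numbers stand for stronger inhibition and higher numbers for weaker inhibition), compound 1 gives 14500 nM. Among the measured compounds shown here, the only other measured member is compound 2, `NC(=O)c1c(NC(=O)c2ccccc2Cl)sc2c1CCN(Cc1cc(Cl)cc(Cl)c1)C2`, which in this assay gives 23700 nM. The step between them, a 1.6-fold higher number from compound 1 to compound 2 (0.21 log units; within the scatter), leaves the two within the scatter, so compound 1 carries the smaller of the two numbers without being separable from compound 2.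

Compound 3, `NC(=O)c1c(NC(=O)c2ccccc2Cl)sc2c1CCN(C(=O)Nc1c(Cl)cccc1Cl)C2`, differs from compound 1 at the same nitrogen that was varied before: (2,6-dichlorophenyl)carbamoyl in place of benzyl on an amine nitrogen in a ring. For the measured compounds named here, the one measured step, from compound 1 to compound 2, only exchanged the aromatic ring of the benzyl group and moved nothing beyond the scatter; it does not cover the loss of the benzyl itself or the entry of a carbamoyl bearing a donor and an acceptor. Going by the values given here, with no step that speaks to this exchange, no shift beyond the scatter is expected in either direction, though the range has to be wide.

Compound 3 is therefore estimated at 15000 nM, with a range of 5000 nM to 50000 nM, which means an expected step of a 1.0-fold higher number from compound 1 to compound 3 (0.01 log units; within the scatter).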

Compound 3, half-maximal inhibitory concentration: 24400 nM
The estimate for compound 3 lay 1.6-fold (0.21 log units) below the measured number; low and high end bracket the measured number.
By their numbers in this assay, from the lowest: compounds 1, 2 and 3 (each within the scatter of the next).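

At the amine nitrogen in a ring, replacing benzyl with (2,6-dichlorophenyl)carbamoyl gives, in this assay, a 1.7-fold higher number from compound 1 to compound 3 (0.23 log units; within the scatter), and replacing 3,5-dichlorobenzyl with the same group gives a 1.0-fold higher number from compound 2 to compound 3 (0.01 log units; within the scatter). This position therefore accepts more than the change on the aromatic ring seen earlier: the benzyl group itself can give way to a carbamoyl group with 11 heavy atoms instead of 7, bringing 1 hydrogen-bond donor and 1 hydrogen-bond acceptor, and the three compounds still cannot be separated on this read-out. No supporting evidence is available to explain why the numbers remain this close.

On these data alone, it remains open whether any group on this nitrogen can move the number beyond the scatter, such as a simple hydrogen, an acetyl group, a longer chain such as phenethyl or a benzyl group carrying a carboxylic acid. A phenylcarbamoyl group without chlorine would also be needed to separate the contribution of the carbamoyl unit from that of the two chlorines in compound 3.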